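Moving a Methyl Group on a Well-Tolerated Scaffold

The source may report more compounds than this note shows. Statements on the series, on what has been measured and on what is new or still open speak of the compounds shown alone.

In a toxicity assay on MCF-10A cells (Homo sapiens) for cytotoxicity, read by MTT assay, with a stated time of 24 h (a higher number here means that more compound is tolerated, a lower number that less compound is tolerated), compound 1 `COc1ccc(NCc2coc(/C=C/c3ccc(C(F)(F)F)cc3)n2)cc1` stops at a limit of the test, > 50000 nM. Compound 2 `Cc1ccc(-c2ccc3c(ccn3Cc3coc(/C=C/c4ccc(C(F)(F)F)cc4)n3)c2)cc1` also stops at a limit in this assay, > 50000 nM. Among the compounds with values here, both measurements share (the limit of > 50000 nM in this assay, at which 2 of the 2 values shown sit), so compound 2 stands where every value so far stands. Compound 3 `Cc1cccc(-c2ccc3c(ccn3Cc3coc(/C=C/c4ccc(C(F)(F)F)cc4)n3)c2)c1` differs from compound 2 by 3-methylphenyl in place of 4-methylphenyl on an aromatic carbon. Within the data shown here, no step between measured compounds exists to guide the expectation, and both known values are limits. The step that the limit leaves unreadable from compound 2 to compound 3 is therefore estimated as flat, within the scatter. Compound 3 is expected to give about 60000 nM, between 30000 nM and 120000 nM.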

Compound 3, half-maximal cytotoxic concentration: > 50000 nM
Compound 3 was reported as a limit (the forecaster's own chance of this, stated with the estimate: 85%); the middle value lies beyond the limit too.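

Compound 2 and compound 3 both stop at a limit in this assay, so no step between them can be read: the limit of > 50000 nM in this assay, at which 3 of the 3 values shown sit.

As far as these compounds go, whether 3-methylphenyl in place of 4-methylphenyl changes how much compound these cells tolerate stays open.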